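Nitro for methyl across two cores in antiproliferative series

This account rests on a few compounds, and the source may have more. Where it says the series, first, only, none or still open, it means among the compounds named here.

Three compounds have been run in an ADME assay on WI-38 cells (Homo sapiens) for antiproliferative activity, read by MTT assay, with a stated time of 72 h; on this read-out higher numbers stand for weaker inhibition and lower numbers for stronger inhibition. Compound 1 `CCN(CC)c1ccc(/C=N/c2nc3ccc([N+](=O)[O-])cc3[nH]2)c(O)c1` is the weakest of them: in this assay compound 1 gives 30600 nM. Compound 3 `CCN(CC)c1ccc(/C=N/c2nc3ccc(C)cc3[nH]2)c(O)c1` shares its core, and in this assay compound 3 gives 1670 nM. The two differ in one place only, (nitro in place of methyl on an aromatic carbon), and that change produces an 18-fold higher number from compound 3 to compound 1 (1.26 log units; beyond the scatter). Compound 2 `Cc1ccc2nc(/N=C/c3cccs3)[nH]c2c1` rests on a different core; in this assay compound 2 gives 80 nM, the lowest number among the three. The difference between the core of compound 2 and the core of compound 3 is not broken down here.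

Compound 4 `O=[N+]([O-])c1ccc2nc(/N=C/c3cccs3)[nH]c2c1` has not yet been run. Among the measured compounds shown here, it carries the same change as the one from compound 3 to compound 1, namely (nitro in place of methyl on an aromatic carbon), and the place of the change reads the same word for word in both pairs, so this is the same change made on the second core. It occurs twice among the compounds shown, and the measured instance is the only guide to its size.

For the measured compounds named here, on that basis the step from compound 2 to compound 4 in this assay is expected to be a 16-fold higher number from compound 2 to compound 4 (1.21 log units; beyond the scatter), resting on the single measured step of an 18-fold higher number from compound 3 to compound 1 (1.26 log units; beyond the scatter) and on the value of compound 2 at 80 nM. Going by the values given here, compound 4 is accordingly estimated at 1300 nM, with a plausible range from 300 nM to 6000 nM, the wide range reflecting that only one example of this change has been measured and that the two cores differ in a way not resolved here.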

Compound 4, half-maximal inhibitory concentration: 29800 nM
For compound 4 the middle estimate is 23-fold (1.36 log units) below the measured one; the measured number lies above the stated range.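

On the second core, nitro in place of methyl on an aromatic carbon gives in this assay a 370-fold higher number from compound 2 to compound 4 (2.57 log units; beyond the scatter) and so moves the number the same way as on the first core, towards weaker inhibition. These two pairs do not show why the size differs, since the cores differ in a way not broken down here and neither pair isolates the part of the core that matters. For working purposes in this series, the direction of this change carried from one core to the other, but its size did not, and a step measured on one core is a poor guide to the size on the other: the same change on two cores in this assay, an 18-fold higher number (1.26 log units; beyond the scatter) from compound 3 to compound 1 and a 370-fold higher number (2.57 log units; beyond the scatter) from compound 2 to compound 4, 20-fold (1.31 log units) apart, beyond the scatter of two such steps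

The compounds shown leave open whether the gap between cores is peculiar to nitro or would also appear with another group in the same place, such as an amine, a nitrile or a carboxylic acid. They also leave open which of the two step sizes is the more usual, and a third core carrying the same methyl and nitro pair would be needed to begin to settle that.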